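This account rests on a few compounds, and the source may have more. Where it says the series, first, only, none or still open, it means among the compounds named here.

In an ADME assay on BJ cells (Homo sapiens) for cytotoxicity, read by luminescence, with a stated time of 72 h (a lower number here means that less compound is needed, a higher number that more compound is needed for the effect), compound 1 `CCOC(=O)c1c(-c2cccc(OC)c2)[nH]c2cc(OC)c(F)cc2c1=O` gives > 21500 nM as a limit of the assay. Compound 2 `CCOC(=O)c1c(-c2cccc(F)c2)[nH]c2cc(OC)c(F)cc2c1=O` gives > 21500 nM as a limit too. Compound 3 `CCOC(=O)c1c(-c2cccc(-c3ccccc3Cl)c2)[nH]c2cc(OC)c(F)cc2c1=O` gives > 21500 nM as a further limit. Compound 3 thus has no number of its own and stands at the limit of > 21500 nM in this assay, at which 3 of the 3 values shown sit, with the other two. Compound 4 `CCOC(=O)c1c(-c2cccc(Oc3c(C)cccc3C)c2)[nH]c2cc(OC)c(F)cc2c1=O` differs from compound 3 by 2,6-dimethylphenoxy in place of 2-chlorophenyl on an aromatic carbon and is still unmeasured. The measured steps give no size to carry over: a step that the two limits leave unreadable from compound 1 to compound 2 and a step that the two limits leave unreadable from compound 1 to compound 3 and a step that the two limits leave unreadable from compound 2 to compound 3 are the only ones available. In this assay the estimated move is a step that the limit leaves unreadable from compound 3 to compound 4 and nothing beyond the scatter is expected. Compound 4 is expected at 25000 nM with an estimated range of 14000 nM to 45000 nM and will most likely be reported as another limit.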

Compound 4, half-maximal effective concentration: > 21500 nM
Compound 4 ended at the assay's limit; the forecaster's own chance of this, stated with the estimate: 85%; the middle value does not contradict the limit.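

No new step can be read between compound 4 and compounds 1, 2 or 3, as all remain limits: the limit of > 21500 nM in this assay, at which 4 of the 4 values shown sit. The compounds shown leave open which change to the shared core, if any, would give a measurable value in this assay.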